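A few compounds are considered here, and "the series" means these few. Any claim that something is new, unique, unknown or untested is made for them only; others in the source may bear on it.

Measured so far in a functional assay on CHO cells for agonist activity at Alpha-1D adrenergic receptor (Homo sapiens), read by FLIPR and calcium flux; on this read-out higher numbers stand for an effect only at larger amounts of compound and lower numbers for an effect already at smaller amounts:
- compound 1 `c1cc(-c2nccs2)c2c(c1)C(c1ncc[nH]1)CC2`: 3190 nM
- compound 2 `Cc1n[nH]cc1-c1cccc2c1CCC2c1ncc[nH]1`: 634 nM
- compound 3 `CS(=O)(=O)Nc1cccc2c1CCCC2c1ncc[nH]1`: only a limit, > 10000 nM; > 10000 nM; > 10000 nM (3 entries)

Compound 2 gives the lowest of the two numbers in this assay; the nearest is compound 1, and the step of a 5.0-fold lower number from compound 1 to compound 2 (0.70 log units; beyond the scatter) lies beyond the scatter. For compound 3 the three repeats report only a limit of the assay, so no number stands for it.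

Compound 4 `Cn1nccc1-c1cccc2c1CCC2c1ncc[nH]1` differs from compound 2 as follows: 1-methyl-1H-pyrazol-5-yl in place of 3-methyl-1H-pyrazol-4-yl on an aromatic carbon. For the measured compounds named here, no measured step covers this pair of groups directly. Going by the values given here, the only step in the set, a 5.0-fold lower number from compound 1 to compound 2 (0.70 log units; beyond the scatter), swaps a ring without a hydrogen-bond donor for one that carries one, and the number falls. The change to compound 4 runs the other way in that respect, the donor leaving while an acceptor enters, with the ring otherwise kept. On that single, indirect precedent the number is expected to rise, by a modest step that is expected as a 2.5-fold higher number from compound 2 to compound 4 (0.40 log units; beyond the scatter).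

Compound 4 in this assay is therefore estimated at 1600 nM, with a range from 500 nM to 5000 nM.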

Compound 4, half-maximal effective concentration: > 10000 nM
Compound 4: only a limit was reported; the forecaster's own chance of this, stated with the estimate: 10%; middle value at least 6.2-fold (0.79 log units) away from the limit.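

In this assay, this position separates two groups with the same heavy atoms: 1-methyl-1H-pyrazol-5-yl in place of 3-methyl-1H-pyrazol-4-yl gives an at least 15-fold higher number from compound 2 to compound 4 (1.19 log units; beyond the scatter), so the way the ring is joined and substituted matters here, not only the kind of ring. Compound 4 gives > 10000 nM, which is a limit of the assay and not a number, so the new steps give only minimum sizes. The lack of a hydrogen-bond donor on the group does not by itself set the read-out, since the 1,3-thiazol-2-yl group has none either and the two groups still differ beyond the scatter, with an at least 3.1-fold higher number from compound 1 to compound 4 (0.49 log units; beyond the scatter).

Going by these compounds, how far compound 4 lies past the top of the measured range stays open, and the step from compound 2 can be read only as a minimum: the limit of > 10000 nM in this assay, at which 1 of the 4 values shown sits. On these data alone, whether the donor or the place of the methyl separates the two pyrazole groups also stays open, and a plain 1H-pyrazol-4-yl group or an amine at this position would bear on that.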